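Cytotoxicity of a quinolone amide series on liver cells

The source may hold more compounds than are shown below. What is called first, only, known or untested is meant among the compounds shown, and "the series" means these compounds.

The compounds here were compared in an ADME assay on Huh-7 cells (Homo sapiens) for cytotoxicity; on this read-out higher numbers stand for weaker inhibition of growth and lower numbers for stronger inhibition of growth. Compound 1, with the structure `COc1cc2c(=O)c(C(=O)c3ccc(C)cc3)cn(CC3CC3)c2cc1OC`, has no single number on this read-out: in this assay compound 1 is recorded as "not active" (no number reported). Compound 2, with the structure `O=C(OCc1ccc(Cl)cc1)c1cn(Cc2ccc(Cl)cc2)c2cc(N3CCNCC3)c(F)cc2c1=O`, gives 1100 nM in this assay. Compound 3, with the structure `CCOC(=O)c1cn(Cc2ccc(Cl)cc2)c2cc(OC)c(OC)cc2c1=O`, is reported only as a limit of the assay in this assay, namely > 15000 nM. That limit is the limit of > 15000 nM in this assay, at which 1 of the 3 values shown sits, so among the values shown only compound 2 carries a definite number, and compound 1 and compound 3 both stand at the weak end of growth inhibition.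

Compound 4, with the structure `COc1cc2c(=O)c(C(=O)c3ccc(C)cc3)cn(Cc3ccc(S(N)(=O)=O)cc3)c2cc1OC`, has not been measured. It differs from compound 1 by 4-sulfamoylphenyl in place of cyclopropyl on a saturated chain carbon bound to an aromatic nitrogen. Among the compounds with values here, with no pair of measured compounds differing in a single place, no step size can be read from the data; what can be said is that two of the three compounds shown sit at or beyond the weak end, and compound 1 itself is among them. On that basis compound 4 is expected to remain weakly active in this assay, with an estimated value of 20000 nM, within a range from 5000 nM to 60000 nM, and with a real chance that the assay again reports only a limit.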

Compound 4, concentration for 50% growth inhibition: > 25000 nM
Compound 4: only a limit was reported; the forecaster's own chance of this, stated with the estimate: 65%; middle value at least 1.2-fold (0.09 log units) from the limit.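

In this assay no step can be read from compound 1 to compound 4, as compound 1 carries no number. Compound 4 gives > 25000 nM and that is only a limit of the assay. The compounds shown leave open whether growth inhibition differs at all between the cyclopropylmethyl and 4-sulfamoylbenzyl compounds.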